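The compounds below may be only part of what the source reports. "The series", "measured", "known", "first", "only" and "open" are said of these compounds alone.

Of the compounds shown here, two built on one shared core have been tested in a functional assay on KB cells (Homo sapiens) for cytotoxicity; a lower number here means a stronger inhibitor, a higher number a weaker inhibitor. Compound 1, with the structure `CC(C)(C)c1ccc(Cn2cc(C(N)=O)c3c(N)ncnc32)cc1`, gives 900 nM in this assay. Compound 2, with the structure `COCCOCn1cc(C(N)=O)c2c(N)ncnc21`, gives in this assay only a limit, > 100000 nM, and not a number. Compound 2 therefore stands at the limit of > 100000 nM in this assay, at which 1 of the 2 values shown sits. The unmeasured compound 3 has the structure `Cc1ccc(Cn2cc(C(N)=O)c3c(N)ncnc32)cc1`. Compound 3 differs from compound 2 in one place: 4-methylphenyl in place of 2-methoxyethoxy on a saturated chain carbon bound to an aromatic nitrogen. Compound 1, which also carries a six-membered aromatic ring of carbon only on the saturated chain carbon bound to an aromatic nitrogen, gives 900 nM, so the step is expected to go toward stronger inhibition by a margin far beyond the usual scatter. The expected step from compound 2 to compound 3 is an at least 50-fold lower number from compound 2 to compound 3 (1.69 log units; beyond the scatter). For compound 3 the estimate in this assay is 2000 nM, with a range from 500 nM to 10000 nM.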

Compound 3, half-maximal inhibitory concentration: > 100000 nM
Compound 3: a limit, no number; the forecaster's own chance of this, stated with the estimate: 10%; at least 50-fold (1.69 log units) between middle value and limit.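

In this assay, putting methyl in place of tert-butyl on an aromatic carbon gives an at least 110-fold higher number from compound 1 to compound 3 (2.04 log units; beyond the scatter). A six-membered aromatic ring of carbon only on the saturated chain carbon bound to an aromatic nitrogen is therefore not enough on its own, and among these compounds the group carried on that ring separates a measurable value from none. The step from compound 2 to compound 3 cannot be read, and both compounds rest at one limit rather than a number: the limit of > 100000 nM in this assay, at which 2 of the 3 values shown sit.

The compounds shown leave open whether ethyl or isopropyl in place of the tert-butyl would give a measurable value. They also leave open how 4-methylphenyl and 2-methoxyethoxy truly rank against each other.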